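Adding a Second Trifluoromethyl Group: Expected Cytotoxicity Shift

The source may report more compounds than this note shows. Statements on the series, on what has been measured and on what is new or still open speak of the compounds shown alone.

Measured compounds:
compound 1, `COc1cc(NC(=O)c2cccc(C(F)(F)F)c2)ccc1NS(C)(=O)=O`: > 250000 nM
compound 2, `COc1cc(NC(=O)c2cc(C(F)(F)F)cc(C(F)(F)F)c2)ccc1NS(C)(=O)=O`: 42000 nM
compound 3, `CCS(=O)(=O)Nc1ccc(NC(=O)c2cccc(C(F)(F)F)c2)cc1F`: 94800 nM

These three amides were tested in an ADME assay on HEK293 cells (Homo sapiens) for cytotoxicity, read by MTT assay, with a stated time of 48 h; on this read-out lower numbers stand for stronger inhibition and higher numbers for weaker inhibition. For compound 1 the result is not a number but a limit of the assay, (the limit of > 250000 nM in this assay, at which 1 of the 3 values shown sits), so compound 1 showed no measurable cytotoxicity up to that point. Compound 2 differs from compound 1 by a single change, (trifluoromethyl in place of hydrogen on an aromatic carbon), and this gave an at least 5.9-fold lower number from compound 1 to compound 2 (0.77 log units; beyond the scatter). Compound 3 carries a different core; how the core of compound 3 differs from the core of compound 1 is not broken down here. In this assay compound 3 gives 94800 nM, the highest of the two actual numbers, and its gap to compound 2 lies beyond the usual scatter.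

Compound 4, `CCS(=O)(=O)Nc1ccc(NC(=O)c2cc(C(F)(F)F)cc(C(F)(F)F)c2)cc1F`, is not yet measured. It relates to compound 3 as compound 2 relates to compound 1: trifluoromethyl in place of hydrogen on an aromatic carbon, the same change in the same kind of surroundings. If the step seen from compound 1 to compound 2 carries over, compound 4 is expected to show a 5.9-fold lower number from compound 3 to compound 4 (0.77 log units; beyond the scatter) in this assay, an expectation resting on compound 1 and compound 2 and their step of an at least 5.9-fold lower number from compound 1 to compound 2 (0.77 log units; beyond the scatter). On that basis compound 4 is estimated at 16000 nM, most plausibly between 5000 nM and 60000 nM.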

Compound 4, half-maximal inhibitory concentration: > 250000 nM
Compound 4: only a limit was reported (the forecaster's own chance of this, stated with the estimate: 5%); middle value at least 15-fold (1.19 log units) away from the limit.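

In this assay compound 4 gives > 250000 nM, which is a limit of the assay and not a number. Adding the second trifluoromethyl group to this core gives an at least 2.6-fold higher number from compound 3 to compound 4 (0.42 log units; beyond the scatter), the opposite direction to the change on the core of compound 1, so in this pair of cores the step does not carry over from one core to the other: the same change on two cores in this assay, an at least 5.9-fold lower number (0.77 log units; beyond the scatter) from compound 1 to compound 2 and an at least 2.6-fold higher number (0.42 log units; beyond the scatter) from compound 3 to compound 4, at least 15-fold (1.19 log units) apart, beyond the scatter of two such steps This shows that the core can matter for the outcome of this change, but it does not show why, and the true size of each step stays unknown, as each step has a limit at one end: the limit of > 250000 nM in this assay, at which 2 of the 4 values shown sit.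

The two cores differ in more than one place, so the compounds shown cannot tell whether the reversal goes with the methoxy group, the fluorine, or the methyl and ethyl chains on the sulfonyl group. Also open, as far as these compounds go, is whether a different group in place of the second trifluoromethyl, such as a nitrile or a chlorine atom, would follow the direction seen on either core.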